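The compounds below may be only part of what the source reports. "The series", "measured", "known", "first", "only" and "open" are said of these compounds alone.

In an ADME assay on MCF-10A cells (Homo sapiens) for cytotoxicity, read by MTT assay, with a stated time of 72 h (on this read-out lower numbers stand for stronger inhibition of growth and higher numbers for weaker inhibition of growth), three compounds of this set have been measured. Compound 1 `CS/C(=N\C(=O)c1sccc1Cl)NC(=O)c1sccc1Cl` gives 23700 nM in this assay. Compound 3 `CS/C(=N\C(=O)c1cnc2ccccc2c1)NC(=O)c1cnc2ccccc2c1` gives 42200 nM, and compound 2 `C[Se]/C(=N\C(=O)c1cnc2ccccc2c1)NC(=O)c1cnc2ccccc2c1` gives 52100 nM. Compound 2 arises from compound 3 by one change, (a group of 2 heavy atoms (1 carbon, 1 selenium; no ring) in place of a group of 2 heavy atoms (1 carbon, 1 sulfur; no ring), on a carbon with a double bond to nitrogen); in this assay that change made a 1.2-fold higher number from compound 3 to compound 2 (0.09 log units; within the scatter). The difference between the core of compound 1 and the core of compound 3 is not broken down here, and the gap between compound 1 and compound 3 is itself within the scatter.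

Compound 4 `C[Se]/C(=N\C(=O)c1sccc1Cl)NC(=O)c1sccc1Cl` has not yet been measured. It arises from compound 1 by the same change, (a group of 2 heavy atoms (1 carbon, 1 selenium; no ring) in place of a group of 2 heavy atoms (1 carbon, 1 sulfur; no ring), on a carbon with a double bond to nitrogen). Among the measured compounds shown here, the only precedent for this change in the set is the pair of compound 3 and compound 2, where it left the number essentially where it was. On that basis the step from compound 1 to compound 4 is expected to be about a 1.2-fold higher number from compound 1 to compound 4 (0.07 log units; within the scatter), because the earlier step of a 1.2-fold higher number from compound 3 to compound 2 (0.09 log units; within the scatter) lay within the scatter. Compound 4 is therefore estimated at 28000 nM in this assay, most likely between 14000 nM and 56000 nM.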

Compound 4, concentration for total growth inhibition: 5490 nM
Beside the measured number, compound 4's estimate is 5.1-fold (0.71 log units) above it; the whole stated range lies above it.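

On the core of compound 1, putting the selenium group in place of methylsulfanyl gave a 4.3-fold lower number from compound 1 to compound 4 (0.64 log units; beyond the scatter) in this assay. Across these two pairs, the effect of the change therefore did not carry over from one core to the other at the same size: the same change on two cores in this assay, a 1.2-fold higher number (0.09 log units; within the scatter) from compound 3 to compound 2 and a 4.3-fold lower number (0.64 log units; beyond the scatter) from compound 1 to compound 4, 5.3-fold (0.73 log units) apart, beyond the scatter of two such steps This shows that the step seen on one core is a poor guide to the step on the other in this series, but it does not show which feature of the core of compound 1 sets the two apart, and with only two pairs it gives no general rule.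

The compounds shown leave open whether a further core would follow the larger step or the step within the scatter. They also leave open what a longer chain on the selenium, such as ethyl, or a methoxy group on the carbon with a double bond to nitrogen, would do on these two cores.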